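Amidine series on fibrosarcoma cells: a benzyl extension

This account rests on a few compounds, and the source may have more. Where it says the series, first, only, none or still open, it means among the compounds named here.

Measured compounds:
compound 1 `CN1CCN(c2ccc(NC(=N)c3cc4cn[nH]c4cn3)cc2)CC1`: 31300 nM
compound 2 `CN1CCN(c2ccc(NC(=N)c3cc4cnn(C)c4cn3)cc2)CC1`: 24000 nM
compound 3 `N=C(Nc1ccccc1)c1cc2cn[nH]c2cn1`: "not determined" (no result reported)

In a functional assay on HT-1080 cells (Homo sapiens) for cytotoxicity, read by MTT assay, with a stated time of 72 h (on this read-out lower numbers stand for stronger inhibition and higher numbers for weaker inhibition), compound 1 gives 31300 nM and compound 2 gives 24000 nM. For the measured compounds named here, the one measured step, a 1.3-fold lower number from compound 1 to compound 2 (0.12 log units; within the scatter), is within the scatter, so the two numbers cannot be put in order. Compound 2 thus stands on a par with compound 1, and for compound 3 the result is "not determined" (no result reported).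

Compound 4 `COc1ccc(Cn2ncc3cc(C(=N)Nc4ccc(N5CCN(C)CC5)cc4)ncc32)cc1` differs from compound 2 by 4-methoxyphenyl in place of hydrogen on a saturated chain carbon bound to an aromatic nitrogen. Going by the values given here, no measured step bears on this change: the only step in the set, from compound 1 to compound 2, concerns the hydrogen to methyl exchange on the aromatic nitrogen and was within the scatter. Among the compounds with values here, that step says nothing about a 4-methoxybenzyl in place of methyl, and no other compound carries such a group.

With nothing to lean on, compound 4 is expected to stay near compound 2, and the step of a 1.2-fold lower number from compound 2 to compound 4 (0.08 log units; within the scatter) is estimated to lie within the scatter. For compound 4 the estimated value in this assay is 20000 nM, in a range from 6000 nM to 60000 nM.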

Compound 4, half-maximal inhibitory concentration: 5300 nM
Compound 4: the middle estimate sits 3.8-fold (0.58 log units) above what was measured, outside the stated range (below it).
By their numbers in this assay, from the lowest: compound 4; then compounds 2 and 1 (each within the scatter of the next).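

In this assay, the substituent on the aromatic nitrogen turns out not to be indifferent: methyl to 4-methoxybenzyl gives a 4.5-fold lower number from compound 2 to compound 4 (0.66 log units; beyond the scatter), and 4-methoxybenzyl in place of hydrogen on the same nitrogen gives a 5.9-fold lower number from compound 1 to compound 4 (0.77 log units; beyond the scatter). Both steps are modest but lie beyond the scatter, whereas the exchange of hydrogen for methyl left compound 1 and compound 2 within the scatter of each other, so this position first shows a readable response with the larger group, which brings in a six-membered aromatic ring of carbon only. Nothing available accounts for this response.

On these data alone, it remains open whether the methoxy group contributes anything, or whether a plain benzyl would serve equally well. As far as these compounds go, it is also open whether a phenethyl group or a chain ending in an amine at this nitrogen would lower the number further.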